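Adding trifluoromethyl to the anilide of compound 3

The compounds below may be only part of what the source reports. "The series", "measured", "known", "first", "only" and "open" are said of these compounds alone.

Compound 1, `O=C(CCCCC(S)CCS)NO`: 28.2%
Compound 2, `O=C(CCCCC1CCSS1)Nc1cccc(C(F)(F)F)c1`: 4.43%
Compound 3, `O=C(CCCCC(S)CCS)Nc1ccccc1`: 3.72%

These values come from a functional assay on Bel-7402 cells (Homo sapiens) for inhibition, read by MTT assay, with a stated time of 24 h, tested at 10 ug/mL; a lower number here means less inhibition of growth, a higher number more inhibition of growth at the concentration tested. In this assay compound 3 gives 3.72%, within the scatter of compound 2 at 4.43%. Within the data shown here, the only measured step is a number 24.5 percentage points lower from compound 1 to compound 3 (beyond the scatter), with phenyl in place of hydroxy on an amide-type nitrogen.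

The next compound is compound 4, `O=C(CCCCC(S)CCS)Nc1cccc(C(F)(F)F)c1`. Its change from compound 3 is trifluoromethyl in place of hydrogen on an aromatic carbon. The measured step lies at another place in the structure, so it gives no direct size for this change. The nearest evidence is compound 2, which carries the same trifluoromethyl but differs from compound 4 elsewhere in the chain. Compound 2 gives 4.43%, close to the value of compound 3, so no step beyond the scatter is expected. The expected step is a number 1.3 percentage points higher from compound 3 to compound 4 (within the scatter). Compound 4 is estimated at 5%, with an expected range from 1% to 14%.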

Compound 4, percent growth inhibition at one concentration: 1.21%
For compound 4 the middle estimate is 3.8 percentage points above the measured one, and the stated range covers the measured number.
By their numbers in this assay, from the lowest: compounds 4, 3 and 2 (each within the scatter of the next); then compound 1.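

In this assay, trifluoromethyl in place of hydrogen on the aromatic carbon, meta to a large group, gives a number 2.5 percentage points lower from compound 3 to compound 4 (within the scatter) and so does not move the reading of the anilide beyond the scatter. With the trifluoromethyl held in place, the open chain in place of the five-membered non-aromatic ring gives a number 3.2 percentage points lower from compound 2 to compound 4 (within the scatter) as well, so neither of these two changes separates the compounds in this assay at the concentration tested. No measurement here offers an explanation for either step.

All three anilides sit close to one another, so the compounds shown leave open whether an amine, a methoxy group or a carboxylic acid in that same place would give a step beyond the scatter. They also leave open whether trifluoromethyl would read the same at another carbon of the ring.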